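The source may report more compounds than this note shows. Statements on the series, on what has been measured and on what is new or still open speak of the compounds shown alone.

Measured compounds in an ADME assay on L02 cells (Homo sapiens) for cytotoxicity, read by MTT assay, with a stated time of 48 h; a lower number here means a stronger inhibitor, a higher number a weaker inhibitor:

- compound 1 `COc1cc(-c2nc3ccc([N+](=O)[O-])cc3[nH]2)cc(-c2nc3ccc([N+](=O)[O-])cc3[nH]2)c1` gives 26300 nM
- compound 2 `Fc1ccc2nc(-c3cccc(-c4nc5ccc(F)cc5[nH]4)c3)[nH]c2c1` gives 20800 nM
- compound 3 `FC(F)(F)c1ccc2nc(-c3cccc(-c4nc5ccc(C(F)(F)F)cc5[nH]4)c3)[nH]c2c1` gives 10900 nM

Compound 3 holds the lowest of the three numbers in this assay. Its nearest neighbour is compound 2, whose number lies within the scatter of that of compound 3, so no order between those two is claimed. Compound 1 stands furthest away, with a number beyond the scatter above that of compound 3.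

Compound 4 `COc1cc(-c2nc3ccc(C(F)(F)F)cc3[nH]2)cc(-c2nc3ccc(C(F)(F)F)cc3[nH]2)c1` is not yet measured. It differs from compound 3 in one place: methoxy in place of hydrogen on an aromatic carbon, meta to two large groups. Going by the values given here, no pair of measured compounds differing only in this way is available, so the size of the step cannot be read from a direct comparison; the three measured numbers all sit in a narrow band, and nothing suggests a large move. The expectation is a step from compound 3 to compound 4 of a 1.2-fold higher number from compound 3 to compound 4 (0.08 log units; within the scatter), no larger than the scatter. Compound 4 is estimated at 13000 nM in this assay, with a range from 6000 nM to 30000 nM.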

Compound 4, half-maximal inhibitory concentration: 10100 nM
Compound 4: middle estimate off by 1.3-fold (0.11 log units), on the high side; measured number inside the range.
By their numbers in this assay, from the lowest: compounds 4, 3, 2 and 1 (each within the scatter of the next, the first and the last beyond it).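

In this assay methoxy in place of hydrogen on an aromatic carbon, meta to two large groups, gives a 1.1-fold lower number from compound 3 to compound 4 (0.03 log units; within the scatter) and so stays within the scatter. Going by these compounds alone, this is the first direct reading of this change, as no two earlier compounds differed in one place only. With trifluoromethyl on both outer ring systems, this position takes methoxy without a measurable shift in the number, and no measurement shown explains that result.

As far as these compounds go, whether this position stays as flat with an amine, a carboxylic acid or a longer alkoxy chain such as butoxy remains open. Also open is whether methoxy gives an equally small step on the fluorine-bearing core of compound 2, since the compounds shown include no such pair.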